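The source may hold more compounds than are shown below. What is called first, only, known or untested is meant among the compounds shown, and "the series" means these compounds.

Measured in a functional assay on NCI-H322M cells (Homo sapiens) for inhibition, read by sulforhodamine B assay, with a stated time of 48 h, tested at 10 uM; a lower number here means a stronger effect, a higher number a weaker effect of the compound at the concentration tested:
compound 1 `COc1cc(Cl)cc(-c2nn(-c3cccc(NC(=O)Nc4cccc(C(F)(F)F)c4)c3)cc2-c2ccncc2)c1` gives 26.2%
compound 2 `COc1cc(Cl)cc(-c2nn(-c3cccc(NC(=O)Nc4ccc(Cl)c(C(F)(F)F)c4)c3)cc2-c2ccncc2)c1` gives 18.7%
compound 3 `COc1cc(Cl)cc(-c2nn(-c3cccc(NC(=O)c4cc(C(F)(F)F)cc(C(F)(F)F)c4)c3)cc2-c2ccncc2)c1` gives 80.3%

Compound 1 sits second highest of the three numbers in this assay; compound 2 is nearest and compound 3 furthest, its number beyond the scatter above that of compound 1. Within the data shown here, the only step measured within this set is a number 7.5 percentage points lower from compound 1 to compound 2 (within the scatter), a change of one substituent that stays within the scatter and says little about a change at the carbonyl carbon.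

Compound 4 `COc1cc(Cl)cc(-c2nn(-c3cccc(NC(=O)c4ccc(Cl)c(Cl)c4)c3)cc2-c2ccncc2)c1` is not yet measured. It differs from compound 1 by 3,4-dichlorophenyl in place of (3-(trifluoromethyl)phenyl)amino on a carbonyl carbon. Among the measured compounds shown here, no measured pair isolates this change. What bears on it is compound 3, which likewise carries a substituted phenyl directly on the carbonyl carbon and gives 80.3%, far higher than compound 1; the aryl groups differ, so this is only a pointer. A step upward, toward a weaker effect, is therefore expected for compound 4, a number 38.8 percentage points higher from compound 1 to compound 4 (beyond the scatter). Compound 4 is estimated at 65%, range 35% to 92%.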

Compound 4, a percentage reported as activity, at one concentration (the size of the read-out at that concentration, not a potency): 84.6%
Beside the measured number, compound 4's estimate is 19.6 percentage points below it; low and high end bracket the measured number.
By their numbers in this assay, from the lowest: compounds 2 and 1 (each within the scatter of the next); then compounds 3 and 4 (each within the scatter of the next).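

The change on the carbonyl carbon now has a direct reading in this assay: a number 58.4 percentage points higher from compound 1 to compound 4 (beyond the scatter), and with (4-chloro-3-(trifluoromethyl)phenyl)amino as the leaving group, a number 65.9 percentage points higher from compound 2 to compound 4 (beyond the scatter). Compound 3 and compound 4 lie within the scatter of each other despite their different aryl groups, so among these four compounds the large difference goes with an arylamino group versus an aryl group directly on the carbonyl carbon, and no compound shown goes against this. No available evidence accounts for the size of these steps.

The compounds shown leave open whether the amino nitrogen itself matters or whether a methylene or an ether oxygen at that point would read the same. Going by these compounds, how a 3,4-dichlorophenylamino group on the carbonyl carbon would read also remains open.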